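The source may report more compounds than this note shows. Statements on the series, on what has been measured and on what is new or still open speak of the compounds shown alone.

Three sulfonamides built on one shared core have been measured in a functional assay on HT-29 cells (Homo sapiens) for inhibition, read by MTT assay, with a stated time of 72 h; a lower number here means a stronger inhibitor of growth, a higher number a weaker inhibitor of growth. Compound 1 `O=S(=O)(NCCCNCc1ccccc1Cl)c1cc(C(F)(F)F)cc(C(F)(F)F)c1` gives 20000 nM. Compound 2 `O=S(=O)(NCCCCNCc1ccc(Br)cc1)c1cc(C(F)(F)F)cc(C(F)(F)F)c1` gives 1600 nM, and compound 3 `O=S(=O)(NCCCNCC1COc2ccccc2O1)c1cc(C(F)(F)F)cc(C(F)(F)F)c1` gives 2200 nM. Compound 2 thus has the lowest number of the three, although compound 3 sits within the scatter of it, so these two cannot be ordered; only compound 1 stands clearly apart from compound 2.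

The unmeasured compound 4 `O=S(=O)(NCCCNCc1ccccc1)c1cc(C(F)(F)F)cc(C(F)(F)F)c1` differs from compound 2 by benzylamino in place of ((4-bromobenzyl)amino)methyl on a saturated chain carbon, three bonds along the chain from a sulfonamide nitrogen. Among the compounds with values here, two measured steps bear on this change. First, a 13-fold lower number from compound 1 to compound 2 (1.10 log units; beyond the scatter), a step that joins a change of the halogenated benzyl group to a change in the link between the two nitrogens. Second, a 9.1-fold lower number from compound 1 to compound 3 (0.96 log units; beyond the scatter), a step in which the link of compound 1 is kept and only the aryl group changes, showing that the arrangement shared by compounds 1 and 3 is compatible with a low number. Within the data shown here, compound 4 carries a benzyl group bearing no halogen, a case none of the measured compounds covers, so the loss of the bromine of compound 2 has no direct precedent. The step is therefore expected to raise the number, but to stay well short of the gap between compound 2 and compound 1, with a 3.1-fold higher number from compound 2 to compound 4 (0.49 log units; beyond the scatter) expected. Compound 4 is estimated at 5000 nM, within a range of 1500 nM to 16000 nM.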

Compound 4, concentration for 50% growth inhibition: 15000 nM
Beside the measured number, compound 4's estimate is 3.0-fold (0.48 log units) below it, and the stated range covers the measured number.
By their numbers in this assay, from the lowest: compounds 2 and 3 (each within the scatter of the next); then compounds 4 and 1 (each within the scatter of the next).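

In this assay, hydrogen in place of chloro on an aromatic carbon gives a 1.3-fold lower number from compound 1 to compound 4 (0.12 log units; within the scatter), so this step, the first to change only that one substituent, lies within the scatter and the two compounds cannot be ordered. The other two steps lie beyond the scatter: a 9.4-fold higher number from compound 2 to compound 4 (0.97 log units; beyond the scatter) and a 6.8-fold higher number from compound 3 to compound 4 (0.83 log units; beyond the scatter), which leaves compound 4 with compound 1 on the high side of both remaining compounds and shows that dropping the chloro alone does not reach the numbers of compound 2 or compound 3. No measurement at hand explains any of these steps.

The step to compound 2 still joins the loss of the bromine to a change in the chain, so a 4-bromobenzyl group on the chain of compound 4, or a plain benzyl group on the chain of compound 2, would be needed to tell these two changes apart. From the compounds shown here alone, how a methoxy or fluoro group on the benzyl ring, or a longer chain than that of compound 2, would fare in this assay also stays open.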